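Methoxy in place of chloro on the shared core: cytotoxicity notes

The source may report more compounds than this note shows. Statements on the series, on what has been measured and on what is new or still open speak of the compounds shown alone.

In an ADME assay on HEK-293T cells (Homo sapiens) for cytotoxicity, read by CCK-8 assay, with a stated time of 48 h (a higher number here means that more compound is tolerated, a lower number that less compound is tolerated), the three measured compounds stand as follows.
Compound 1 `O=C(CSc1c[nH]c2cccc(Cl)c12)Nc1ccc(Cl)c(Cl)c1` gives 34700 nM.
Compound 2 `O=C(CSc1c[nH]c2c(Cl)cccc12)Nc1ccc(Cl)c(Cl)c1` gives 49100 nM.
For compound 3 `COc1cccc2[nH]cc(SCC(=O)Nc3ccc(Cl)c(Cl)c3)c12` the value > 100000 nM is a limit of the assay, not a number.

Compound 1 and compound 2 are built from the same atoms joined differently; the difference between the two cores is not broken down here. Their two numbers in this assay lie within the usual scatter of each other, so no order between compound 1 and compound 2 is read from them.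

Compound 3 differs from compound 1 by one change (methoxy in place of chloro on an aromatic carbon). That change made the step of an at least 2.8-fold higher number from compound 1 to compound 3 (0.45 log units; beyond the scatter), which is open-ended because of the limit of > 100000 nM in this assay, at which 1 of the 3 values shown sits.

Compound 4 `COc1cccc2c(SCC(=O)Nc3ccc(Cl)c(Cl)c3)c[nH]c12` is not yet measured. It differs from compound 2 by methoxy in place of chloro on an aromatic carbon. The place description is identical word for word to that of the change from compound 1 to compound 3, so this is the same change on a core that differs only in how the same atoms are joined.

Starting from compound 2 at 49100 nM, the expectation for compound 4 is a step of about a 2.9-fold higher number from compound 2 to compound 4 (0.46 log units; beyond the scatter), resting on the step from compound 1 to compound 3 in this assay. Compound 4 is therefore estimated at 140000 nM, with a range from 60000 nM to 400000 nM, and a real chance that the assay again returns only a limit.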

Compound 4, half-maximal cytotoxic concentration: > 100000 nM
Compound 4: no number, only a limit; the forecaster's own chance of this, stated with the estimate: 70%; the middle value does not contradict the limit.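

In this assay, methoxy in place of chloro on an aromatic carbon gives an at least 2.0-fold higher number from compound 2 to compound 4 (0.30 log units; that floor lies within the scatter) on the core of compound 2. Compound 4 stands at a limit of the assay, so this step is only a floor rather than a measured size, and that floor alone does not clear the scatter. Nothing here shows the change behaving differently on the two cores, but it does not show an equal size on both either, so the change is consistent across this one pair of cores without being established as a transferable step of known size: the same change on two cores in this assay, an at least 2.8-fold higher number (0.45 log units; beyond the scatter) from compound 1 to compound 3 and an at least 2.0-fold higher number (0.30 log units; that floor lies within the scatter) from compound 2 to compound 4; the limit leaves it open whether they differ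

The ceiling also hides how much further the methoxy compounds might go on either core, and the series has little room left for reading differences at this end: the limit of > 100000 nM in this assay, at which 2 of the 4 values shown sit.

The compounds shown leave open whether other groups at these two places, such as an amine, a carboxylic acid or ethoxy as a longer chain, would give numbers that can be read in full. They also leave open whether the change would carry over if the two chloro groups on the amide's aromatic ring were replaced.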